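Swapping 3-hydroxycyclopentyl for 3-aminocyclopentyl

The source may report more compounds than this note shows. Statements on the series, on what has been measured and on what is new or still open speak of the compounds shown alone.

In an ADME assay on microsomes from liver (Mus musculus) for metabolic stability, read by LC-MS, using NADPH, with a stated time of 10 min, tested at 10 uM (a lower number here means that the compound disappears faster, a higher number that the compound lasts longer), compound 1 `Nc1ncnc2c1c(Oc1cc(C(F)(F)F)ccn1)nn2C1CC1` gives > 2.41 h, which is a limit of the assay and not a number. For the measured compounds named here, compound 2 `Nc1ncnc2c1c(Oc1cc(C(F)(F)F)ccn1)nn2C1CCC(O)C1`, with 3-hydroxycyclopentyl on the aromatic nitrogen, gives 0.3 h, the only actual number so far. Going by the values given here, the single measured step is an at least 8.0-fold lower number from compound 1 to compound 2 (0.90 log units; beyond the scatter), and it replaced cyclopropyl at that same place.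

Compound 3 `Nc1ncnc2c1c(Oc1cc(C(F)(F)F)ccn1)nn2[C@@H]1CC[C@H](N)C1` has 3-aminocyclopentyl in place of 3-hydroxycyclopentyl on that aromatic nitrogen: 3-aminocyclopentyl in place of 3-hydroxycyclopentyl on an aromatic nitrogen. The five-membered ring stays here, whereas the measured step of an at least 8.0-fold lower number from compound 1 to compound 2 (0.90 log units; beyond the scatter) exchanged the whole group, so it sets no size for this change. From the compounds shown here alone, no measurement covers an exchange of oxygen for nitrogen in this group, and the direction remains open. The expected step is small and within the scatter: a 1.2-fold higher number from compound 2 to compound 3 (0.07 log units; within the scatter). Compound 3 is estimated at 0.35 h, with an expected range of 0.15 h to 0.9 h.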

Compound 3, half-life: 1.4 h
Compound 3: the middle estimate sits 4.0-fold (0.60 log units) below what was measured; the measured number lies above the stated range.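

With the five-membered ring kept, the exchange on the aromatic nitrogen gives a 4.7-fold higher number from compound 2 to compound 3 (0.67 log units; beyond the scatter) in this assay, so the ring alone does not fix the short half-life of compound 2. Against cyclopropyl, the step is an at least 1.7-fold lower number from compound 1 to compound 3 (0.23 log units; that floor lies within the scatter), so these data do not establish a real loss from the cyclopropyl compound once the group is 3-aminocyclopentyl. For compound 1, > 2.41 h is a limit of the assay and not a number: the limit of > 2.41 h in this assay, at which 1 of the 3 values shown sits.

From the compounds shown here alone, only one stereoisomer of 3-aminocyclopentyl appears here, so the part played by its 2 defined stereocentres in this step stays open. Also open, going by these compounds, is what 3-(dimethylamino)cyclopentyl, a carboxylic acid on the cyclopentyl ring, or an amine on the cyclopropyl ring would give in this assay.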